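The source may hold more compounds than are shown below. What is called first, only, known or untested is meant among the compounds shown, and "the series" means these compounds.

Among the measured compounds shown here, in an ADME assay on microsomes from liver (Homo sapiens) for metabolic stability, read by LC-MS, using NADPH, with stated times of 5 min and 30 min, tested at 1 uM (a lower number here means slower removal, a higher number faster removal of the compound), two compounds on a shared core have numbers so far. Compound 1 (`CC(=O)N1CCC(c2cnc(NCc3c(F)ccc4c3CCO4)c3cn[nH]c(=O)c23)CC1`) gives 207 mL.min-1.g-1 and compound 2 (`Cc1ncc(-c2cnc(NCc3c(F)ccc4c3CCO4)c3cn[nH]c(=O)c23)n1C`) gives 10 mL.min-1.g-1 as the lower of the two. Compound 3 (`CNC(=O)c1ncc(-c2cnc(NCc3c(F)ccc4c3CCO4)c3cn[nH]c(=O)c23)n1C`) differs from compound 2 by methylcarbamoyl in place of methyl on an aromatic carbon, between two ring nitrogen atoms (methylcarbamoyl in place of methyl on an aromatic carbon). The group thus goes from 1,2-dimethyl-1H-imidazol-5-yl to 1-methyl-2-(methylcarbamoyl)-1H-imidazol-5-yl. For the measured compounds named here, only one measured step is available, a large one (a 21-fold lower number from compound 1 to compound 2 (1.32 log units; beyond the scatter)). It exchanges the whole group on the core, so it bears on this change only indirectly. Going by the values given here, no measured step alters a group on the ring of compound 2, and the data give no direct measure for this replacement. With compound 2 at 10 mL.min-1.g-1 as the starting point, no step beyond the scatter is expected in this assay, with a slight lean towards a higher number. The expected step is a 1.4-fold higher number from compound 2 to compound 3 (0.15 log units; within the scatter) on this reasoning. For compound 3 the estimated value is 14 mL.min-1.g-1 within an expected range from 6 mL.min-1.g-1 to 35 mL.min-1.g-1 for now.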

Compound 3, intrinsic clearance in microsomes: 24 mL.min-1.g-1
For compound 3 the middle estimate is 1.7-fold (0.23 log units) below the measured one; measured number inside the range.
By their numbers in this assay, from the lowest: compound 2; then compound 3; then compound 1.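

In this assay the aromatic carbon between two ring nitrogen atoms now has a measured change of its own: methylcarbamoyl in place of methyl gives a 2.4-fold higher number from compound 2 to compound 3 (0.38 log units; beyond the scatter), so a substitution at this place on the five-membered aromatic ring registers beyond the scatter, though the step is modest. Carrying the larger group, the 1-methyl-2-(methylcarbamoyl)-1H-imidazol-5-yl compound still stands well apart from the 1-acetylpiperidin-4-yl compound, with an 8.6-fold lower number from compound 1 to compound 3 (0.94 log units; beyond the scatter), which means that compound 2 and compound 3 both lie far lower than compound 1 and that the change at this position gives back only a part of the earlier separation. Nothing available on these compounds accounts for the movement at this position.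

Open, from the compounds shown here alone, is whether a carboxylic acid, a nitrile or a longer chain on the amide nitrogen at this same carbon would move the number in the same direction and by a similar amount. Also open, going by these compounds, is how the step would read with an ethyl group on the ring atom that now bears a methyl group.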